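The source may report more compounds than this note shows. Statements on the series, on what has been measured and on what is new or still open speak of the compounds shown alone.

Measured so far in a functional assay on the whole organism with Mus musculus as the target; on this read-out lower numbers stand for an effect already at smaller amounts and higher numbers for an effect only at larger amounts of compound:
- compound 1 `Cc1c(N)cc2c(c1C)OC(C)(C)C2` gives 24.4 mg/kg
- compound 2 `Cc1c(C)c2c(c([N+](=O)[O-])c1N)CC(C)(C)O2` gives > 100 mg/kg as a limit
- compound 3 `Cc1c(C)c2c(c(C)c1N)CC(C)(CSc1ccc(F)cc1)O2` gives 17.9 mg/kg

Compound 3 at 17.9 mg/kg and compound 1 at 24.4 mg/kg lie within the scatter of each other. Compound 2 reports > 100 mg/kg as a limit only, so it has no exact number.

Compound 4 `Cc1c(C)c2c(c(C)c1N)CC(C)(CSCCO)O2` carries 2-hydroxyethyl in place of 4-fluorophenyl on a sulfur and keeps the rest of compound 3 unchanged.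

Among the measured compounds shown here, the only measured single-place step is an at least 4.0-fold higher number from compound 1 to compound 2 (0.61 log units; beyond the scatter) for nitro in place of hydrogen on an aromatic carbon. That step lies elsewhere on the shared core, so it shows only that one substitution can move this read-out beyond the scatter. For the measured compounds named here, no measured step touches the group on sulfur. Compound 1, at 24.4 mg/kg with no sulfur chain at all, still sits within the scatter of compound 3, although the two also differ elsewhere.

A large shift in this assay is therefore not expected, only a lean towards a higher number. The expected change is a 1.7-fold higher number from compound 3 to compound 4 (0.22 log units; within the scatter) and would stay within the scatter. For compound 4 the estimated dose is 30 mg/kg, with an expected range from 12 mg/kg to 80 mg/kg.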

Compound 4, dose for 50% inhibition: > 50 mg/kg
Compound 4 gave a limit, no number; the forecaster's own chance of this, stated with the estimate: 15%; middle value at least 1.6-fold (0.22 log units) from the limit.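

In this assay, the group on sulfur proves to be a place that responds to change: 2-hydroxyethyl in place of 4-fluorophenyl gives an at least 2.7-fold higher number from compound 3 to compound 4 (0.44 log units; beyond the scatter). Among the compounds shown here, the earlier compounds showed a step beyond the scatter only for nitro in place of hydrogen on an aromatic carbon, so this is the first sign that the read-out also depends on what sits on the sulfur, and here the change runs towards a higher number, with the six-membered aromatic ring leaving and a chain with no ring entering. Compound 4 stands only as a limit, so the step has a lower bound and no exact size: the limit of > 50 mg/kg in this assay, at which 1 of the 4 values shown sits.

The compounds shown do not separate the loss of the 4-fluorophenyl ring from the arrival of the hydroxyl, and a plain phenyl, an ethyl or a longer chain on the same sulfur would help to tell these apart. From the compounds shown here alone, how much the sulfur link itself contributes also stays open, a question that a sulfone or an ether oxygen at that place could address.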